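A few compounds are considered here, and "the series" means these few. Any claim that something is new, unique, unknown or untested is made for them only; others in the source may bear on it.

Working notes on the series, read in a functional assay on U-266 cells (Homo sapiens) for antiproliferative activity, read by MTT assay, with a stated time of 72 h (a higher number here means a weaker inhibitor, a lower number a stronger inhibitor), on a shared core. Here compound 1 (`C[C@H](NC(=O)/C(C#N)=C/c1cccc(Br)n1)c1ccc(Br)cc1`) gives 1800 nM and compound 2 (`COc1cccc([C@H](C)NC(=O)/C(C#N)=C/c2cccc(Br)n2)c1`) gives 2800 nM as its value. Among the compounds with values here, the only measured step, a 1.6-fold higher number from compound 1 to compound 2 (0.19 log units; within the scatter), replaces 4-bromophenyl with 3-methoxyphenyl on a saturated chain carbon bound to an amide-type nitrogen and a saturated chain carbon. Compound 2 therefore stands within the scatter of compound 1, and the two cannot be ranked.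

Compound 3 (`C[C@H](NC(=O)/C(C#N)=C/c1cccc(Br)n1)c1ccccc1F`) changes the same place, with 2-fluorophenyl in place of 3-methoxyphenyl on a saturated chain carbon bound to an amide-type nitrogen and a saturated chain carbon. The step from compound 1 to compound 2 is the only one that bears on this change, and it shows two different aryl groups at this place giving values within the scatter. Within the data shown here, no measured compound carries a fluorophenyl group, so that single step is weak evidence. No shift beyond the scatter is expected in this assay on this basis, in either direction. The estimated change is a 1.2-fold lower number from compound 2 to compound 3 (0.07 log units; within the scatter) and remains an expectation only. For compound 3 the expected value is 2400 nM (1100 nM to 5500 nM).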

Compound 3, half-maximal inhibitory concentration: 2000 nM
Estimate against measurement, compound 3: 1.2-fold (0.08 log units) above; low and high end bracket the measured number.
By their numbers in this assay, from the lowest: compounds 1, 3 and 2 (each within the scatter of the next).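

In this assay the 2-fluorophenyl group of compound 3 gives a third aryl group at this place, on a saturated chain carbon bound to an amide-type nitrogen and a saturated chain carbon, with a 1.4-fold lower number from compound 2 to compound 3 (0.15 log units; within the scatter) and with a 1.1-fold higher number from compound 1 to compound 3 (0.05 log units; within the scatter) as well. The earlier single step now has company: 4-bromophenyl, 3-methoxyphenyl and 2-fluorophenyl all read within the scatter of one another, so compound 1, compound 2 and compound 3 cannot be ranked, and this change separates nothing in this assay. No measurement at hand bears on why these three aryl groups read alike.

On these data alone, all three groups at this place are substituted phenyl rings, so it remains open whether a saturated cyclohexyl ring, a longer chain carrying the ring, or a phenyl ring bearing an amine or a carboxylic acid would stay within the scatter of these values. Also open, as far as these compounds go, is whether the unsubstituted phenyl group would read alike, and whether the opposite configuration at the saturated chain carbon would leave the values where they stand.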